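Furan to Hydroxyphenyl on a Saturated Ring Carbon

This account rests on a few compounds, and the source may have more. Where it says the series, first, only, none or still open, it means among the compounds named here.

Compound 1 `CC1=C(C(=O)OCc2ccccn2)C(c2ccco2)C2=C(CCCC2=O)N1` gives in a physicochemical assay for lipophilicity, measured as octanol-water partition (a lower number here means a more polar compound, a higher number a more lipophilic compound), a value of 1.4. Its nearest neighbour is compound 3 `CC1=C(C(=O)OCc2cccnc2)C(c2cccs2)C2=C(CCCC2=O)N1`, which in this assay gives 1.4, so the two stand level at the digits printed and together form the lowest pair of the three numbers. Among the measured compounds shown here, the furthest is compound 2 `CC1=C(C(=O)OCc2cccnc2)C(c2ccccc2)C2=C(CCCC2=O)N1`, which in this assay gives 2.35; the one measured step, a number 0.95 log units lower from compound 2 to compound 3 (beyond the scatter), separates it from compound 3.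

Compound 4 `CC1=C(C(=O)OCc2ccccn2)C(c2cccc(O)c2)C2=C(CCCC2=O)N1` differs from compound 1 in one place: 3-hydroxyphenyl in place of furan-2-yl on a saturated ring carbon. For the measured compounds named here, the only measured step that bears on this change is a number 0.95 log units lower from compound 2 to compound 3 (beyond the scatter), which shows a six-membered carbon ring against a five-membered one at this position. Since compound 1 stands level with compound 3, a bare phenyl in place of furan-2-yl would be expected to raise the number by about that amount, because of a number 0.95 log units lower from compound 2 to compound 3 (beyond the scatter). Going by the values given here, no measured pair shows what the hydroxy group on the entering ring does, so part of that rise is taken back in the estimate. The expected step is a number 0.30 log units higher from compound 1 to compound 4 (within the scatter), a modest rise at most. Compound 4 is therefore estimated at 1.7, with a range from 1.1 to 2.3.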

Compound 4, partition coefficient: 1.58
Compound 4: the middle estimate sits 0.12 log units above what was measured; measured number inside the range.
By their numbers in this assay, from the lowest: compounds 1, 3 and 4 (each within the scatter of the next); then compound 2.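

In this assay, the change from furan-2-yl to 3-hydroxyphenyl on this saturated ring carbon gives a number 0.18 log units higher from compound 1 to compound 4 (within the scatter), so compound 4 cannot be told apart from compound 1 in this read-out. The earlier compounds shown here showed a step beyond the scatter when a five-membered aromatic ring took the place of a six-membered one here, a number 0.95 log units lower from compound 2 to compound 3 (beyond the scatter), whereas the new pair shows that a six-membered aromatic ring carrying a hydroxy group can enter this position without such a step. Compounds 1 and 4 differ from compounds 2 and 3 in a second place, so the two steps stand side by side as separate observations and do not yet form a rule for this position.

The compounds shown leave open how much of the new step belongs to the six-membered ring and how much to the hydroxy group, and whether an amine or a carboxylic acid in place of that hydroxy group would also stay within the scatter of compound 1. Nothing in the available evidence explains why the step is this small.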